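Swapping the Amine Substituent in a Sulfone Series

The source may report more compounds than this note shows. Statements on the series, on what has been measured and on what is new or still open speak of the compounds shown alone.

Compound 1 `NC(=O)CNC[C@@H]1CCCc2cc(S(=O)(=O)c3cccc(F)c3)ccc21` gives 0.1 nM in an assay on isolated protein for displacement of a labelled ligand from 5-hydroxytryptamine receptor 6 (Homo sapiens); on this read-out lower numbers stand for stronger inhibition and higher numbers for weaker inhibition. For the measured compounds named here, compound 2 `CN(CC(N)=O)C[C@@H]1CCCc2cc(S(=O)(=O)c3cccc(F)c3)ccc21` gives 1.26 nM in this assay, the higher of the two numbers; the one measured step is a 13-fold higher number from compound 1 to compound 2 (1.10 log units; beyond the scatter), a large one. Compound 3 `O=S(=O)(c1cccc(F)c1)c1ccc2c(c1)CCC[C@H]2CNCCO` carries the change ((2-hydroxyethyl)amino in place of (carbamoylmethyl)(methyl)amino on a saturated chain carbon bound to a saturated ring carbon). Going by the values given here, the methyl on the amine nitrogen is removed again here, so that step bears on it, but the hydroxyethyl chain has no measured precedent. A moderate drop in number is expected. Compound 3 is therefore estimated at 0.3 nM, within 0.08 nM to 1.5 nM, an expected step of a 4.2-fold lower number from compound 2 to compound 3 (0.62 log units; beyond the scatter).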

Compound 3, inhibition constant: 0.126 nM
The estimate for compound 3 lay 2.4-fold (0.38 log units) above the measured number; measured number inside the range.
By their numbers in this assay, from the lowest: compounds 1 and 3 (each within the scatter of the next); then compound 2.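

The carbamoyl group is not needed for a low number at this chain end: with hydroxymethyl in its place, this assay shows a 1.3-fold higher number from compound 1 to compound 3 (0.10 log units; within the scatter), so the two compounds cannot be told apart. The a 10-fold lower number from compound 2 to compound 3 (1.00 log units; beyond the scatter) therefore fits the loss of the methyl on the amine nitrogen more than the change of chain end, though this step changes both at once. No measured evidence explains why either group is accepted here. Still open, as far as these compounds go, is whether a carboxylic acid or an amine at the chain end would keep the number this low, and whether a longer chain would.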